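The compounds below may be only part of what the source reports. "The series", "measured", "known", "first", "only" and "open" are said of these compounds alone.

Compound 1 `CCCN(c1ccnc(Nc2ccc(C#N)cc2)n1)c1c(F)cc(-c2ccc(C#N)cc2)cc1F`: in an ADME assay on MT4 cells (Homo sapiens) for cytotoxicity, read by MTT assay, with a stated time of 5 days (a higher number here means that more compound is tolerated, a lower number that less compound is tolerated), compound 1 gives 212000 nM.
Compound 2 `N#Cc1ccc(Nc2nccc(N(CCCO)c3c(F)cc(-c4ccc(C#N)cc4)cc3F)n2)cc1`: in this assay compound 2 gives 68000 nM.
Compound 3 `N#Cc1ccc(Nc2nccc(N(CC(O)CO)c3c(F)cc(-c4ccc(C#N)cc4)cc3F)n2)cc1`: in this assay compound 3 gives 19500 nM.

Compound 3 has the lowest number of the three. Compound 2 lies nearest, a 3.5-fold lower number from compound 2 to compound 3 (0.54 log units; beyond the scatter), and compound 1 furthest, an 11-fold lower number from compound 1 to compound 3 (1.04 log units; beyond the scatter). Compound 4 `CC(=O)N(c1ccnc(Nc2ccc(C#N)cc2)n1)c1c(F)cc(-c2ccc(C#N)cc2)cc1F` differs from compound 3 by acetyl in place of 2,3-dihydroxypropyl on a nitrogen on an aromatic ring. For the measured compounds named here, no measured step introduces an acetyl; the nearest guides are a 3.1-fold lower number from compound 1 to compound 2 (0.49 log units; beyond the scatter) and a 3.5-fold lower number from compound 2 to compound 3 (0.54 log units; beyond the scatter), both of which lowered the number as hydroxy groups were added. Compound 4 carries no hydroxy group, so in this assay a rise is expected, a 7.7-fold higher number from compound 3 to compound 4 (0.89 log units; beyond the scatter). Compound 4 is accordingly estimated at about 150000 nM, within a range of 50000 nM to 400000 nM.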

Compound 4, half-maximal cytotoxic concentration: > 268000 nM
Compound 4: no number, only a limit (the forecaster's own chance of this, stated with the estimate: 15%); at least 1.7-fold (0.25 log units) between middle value and limit.
By their numbers in this assay, from the lowest: compound 3; then compound 2; then compound 1. At a limit, above all of these: compound 4.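

In this assay compound 4 gives > 268000 nM, which is a limit and not a number. On this nitrogen, acetyl, with no hydrogen-bond donors, sets the number apart from both hydroxy-bearing chains, with an at least 13-fold higher number from compound 3 to compound 4 (1.13 log units; beyond the scatter) and an at least 3.9-fold higher number from compound 2 to compound 4 (0.59 log units; beyond the scatter). Against propyl, the step, an at least 1.2-fold higher number from compound 1 to compound 4 (0.10 log units; that floor lies within the scatter), establishes no order.

On these data alone, whether an amine or a carboxylic acid on this nitrogen would lower the number as the hydroxy groups did remains open, as does where a longer chain would fall. As far as these compounds go, the true distance between acetyl and propyl also remains open.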